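Cytotoxicity of two chalcone amides and a nitro analogue

The source may report more compounds than this note shows. Statements on the series, on what has been measured and on what is new or still open speak of the compounds shown alone.

compound 1 `COC(=O)c1cc(-c2cccc(NC(=O)c3ccc(/C=C/C(=O)c4ccc(C)cc4)cc3)c2)on1`: > 80 ug/mL
compound 2 `COC(=O)c1cc(-c2cccc(NC(=O)c3ccc(/C=C/C(=O)c4ccc(C)c(F)c4)cc3)c2)on1`: > 50 ug/mL

In an ADME assay on Vero cells (Chlorocebus sabaeus) for cytotoxicity, read by MTT assay, with a stated time of 72 h (a higher number here means that more compound is tolerated, a lower number that less compound is tolerated), compound 1 shows only a limit, > 80 ug/mL. Compound 2 also shows only a limit in this assay, > 50 ug/mL. The step that the two limits leave unreadable from compound 1 to compound 2 therefore cannot be sized: compound 1 sits at the limit of > 80 ug/mL in this assay, at which 1 of the 2 values shown sits, and compound 2 sits at the limit of > 50 ug/mL in this assay, at which 1 of the 2 values shown sits. Compound 3 `COC(=O)c1cc(-c2cccc(NC(=O)c3ccc(/C=C/C(=O)c4ccc(C)c([N+](=O)[O-])c4)cc3)c2)on1` differs from compound 2 by nitro in place of fluoro on an aromatic carbon. Within the data shown here, no measured step bears on this change. Since compound 2 stands at a limit, compound 3 is expected to remain tolerated at a similar level, with a step that the limit leaves unreadable from compound 2 to compound 3 not beyond the scatter, giving an estimated 60 ug/mL in the range 25 ug/mL to 100 ug/mL.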

Compound 3, half-maximal cytotoxic concentration: > 80 ug/mL
Compound 3 ended at the assay's limit; the forecaster's own chance of this, stated with the estimate: 65%; middle value at least 1.3-fold (0.12 log units) from the limit.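

In this assay compound 3 gives > 80 ug/mL, which is a limit. Compound 1 and compound 2 also show only limits, so no step among these three compounds can be read. As far as these compounds go, the concentration at which any of them becomes toxic to the cells remains open.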